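The compounds below may be only part of what the source reports. "The series", "measured", "known", "first", "only" and "open" are said of these compounds alone.

In a functional assay on HepG2 cells (Homo sapiens), read by MTT assay, with a stated time of 48 h (a lower number here means a stronger inhibitor, a higher number a weaker inhibitor), compound 3 (`CCN(CC)CCCNC(=O)c1ccc(C(CC)(CC)c2ccc(OCC(O)C(C)(C)C)c(C)c2)n1CC`) gives 1100 nM, the highest of the three numbers, while compound 2 (`CCN(CC)CCNC(=O)c1ccc(C(CC)(CC)c2ccc(OCC(O)C(C)(C)C)c(C)c2)n1CC`) gives 490 nM and compound 1 (`CCn1c(C(=O)NCCN)ccc1C(CC)(CC)c1ccc(OCC(=O)C(C)(C)C)c(C)c1`) gives 180 nM. Compound 4 (`CCn1c(C(=O)NCCN)ccc1C(CC)(CC)c1ccc(OCC(O)C(C)(C)C)c(C)c1`) differs from compound 3 as follows: amino in place of (diethylamino)methyl on a saturated chain carbon, two bonds along the chain from an amide-type nitrogen. This places amino on a saturated chain carbon, two bonds along the chain from an amide-type nitrogen. Within the data shown here, the one measured step at this place is a 2.2-fold higher number from compound 2 to compound 3 (0.35 log units; beyond the scatter). Compound 1, which also carries 2-aminoethyl, gives 180 nM. On these grounds, a modest to moderate move to a lower number is expected in this assay, and the expected step is a 3.1-fold lower number from compound 3 to compound 4 (0.50 log units; beyond the scatter). For compound 4 the estimate is 350 nM, with an expected range of 140 nM to 850 nM.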

Compound 4, half-maximal inhibitory concentration: 176 nM
Estimate against measurement, compound 4: 2.0-fold (0.30 log units) above; measured number inside the range.
By their numbers in this assay, from the lowest: compounds 4 and 1 (each within the scatter of the next); then compound 2; then compound 3.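

In this assay amino in place of (diethylamino)methyl gives a 6.3-fold lower number from compound 3 to compound 4 (0.80 log units; beyond the scatter) and amino in place of diethylamino gives a 2.8-fold lower number from compound 2 to compound 4 (0.44 log units; beyond the scatter) on this chain. The second step shows that removing the diethyl substitution matters with the chain unchanged, which the earlier diethylamino pair could not show. With 2-aminoethyl in place, 1-hydroxy-2,2-dimethylpropyl for (tert-butyl)carbonyl gives a 1.0-fold lower number from compound 1 to compound 4 (0.01 log units; within the scatter) and so separates nothing in this assay.

On these data alone, whether methylamino, a piperidine or a longer chain ending in amino would match compound 4 remains open. No supporting evidence bears on why these steps arise.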